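The source may hold more compounds than are shown below. What is called first, only, known or untested is meant among the compounds shown, and "the series" means these compounds.

Working notes on the series, which shares the core of compound 2 `N#C/C(=C\N1CCN(C(=O)c2ccco2)C1=S)C(N)=O` throughout.

In a functional assay on MDA-MB-435 cells (Homo sapiens) for inhibition, read by sulforhodamine B assay, with a stated time of 48 h (on this read-out lower numbers stand for stronger inhibition of growth and higher numbers for weaker inhibition of growth), compound 2 gives 14600 nM. Its only comparator, compound 1 `N#C/C(=C\N1CCN(C(=O)c2ccco2)C1=S)C(=O)Nc1ccc(Cl)cc1`, gives 15200 nM in this assay; the two numbers lie within the scatter of each other, so on the numbers shown compound 2 stands alongside compound 1 with no separation, and the series so far occupies a single narrow band.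

Compound 3 `N#C/C(=C\N1CCN(C(=O)c2ccco2)C1=S)C(=O)c1ccccc1` is the next member. It differs from compound 2 by phenyl in place of amino on a carbonyl carbon. Among the compounds with values here, the one measured step that bears on this position, a 1.0-fold lower number from compound 1 to compound 2 (0.02 log units; within the scatter), shows that exchanging the substituent on the amide-type nitrogen left this assay unmoved. Within the data shown here, the change to compound 3 reaches one bond closer in, onto the carbonyl carbon itself, and no measured step probes that exactly; the only guidance is that this end of the molecule has so far been tolerant. A step of a 1.2-fold lower number from compound 2 to compound 3 (0.09 log units; within the scatter) is therefore expected, that is, nothing clearly beyond the scatter. Compound 3 is estimated at 12000 nM, with a range from 4000 nM to 36000 nM.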

Compound 3, concentration for 50% growth inhibition: 11000 nM
The estimate for compound 3 lay 1.1-fold (0.04 log units) above the measured number; low and high end bracket the measured number.
By their numbers in this assay, from the lowest: compounds 3, 2 and 1 (each within the scatter of the next).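

In this assay, the change reaches the carbonyl carbon itself, and the result is a 1.3-fold lower number from compound 2 to compound 3 (0.12 log units; within the scatter); the larger exchange of (4-chlorophenyl)amino for phenyl gives a 1.4-fold lower number from compound 1 to compound 3 (0.14 log units; within the scatter). Amino, (4-chlorophenyl)amino and phenyl on this carbonyl carbon therefore show no separation, so the series stays in one band even when the amide-type nitrogen and its hydrogen-bond donor are gone and a six-membered aromatic ring enters directly. No supporting data bear on why these groups are interchangeable here.

On these data alone, it remains open whether any group at this position can move the number beyond the scatter, for example a carboxylic acid, a basic amine or a longer alkyl chain. The compounds shown also leave open how the number responds to changes elsewhere on the shared core.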